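This account rests on a few compounds, and the source may have more. Where it says the series, first, only, none or still open, it means among the compounds named here.

Measured compounds:
Compound 1 `CCCCn1cnc2c(Nc3cccc(Cl)c3)nc(NCOCc3ccc(/C=C/C(=O)Nc4ccccc4N)cc3)nc21`: 25.7% in a functional assay on NCI-H460 cells (Homo sapiens) for antiproliferative activity, read by CCK-8 assay, with a stated time of 72 h, tested at 2 uM; a lower number here means a weaker effect, a higher number a stronger effect of the compound at the concentration tested
Compound 2 `Nc1ccccc1NC(=O)/C=C/c1ccc(COCNc2nc(Nc3cccc(Cl)c3)c3ncn(C4CCCC4)c3n2)cc1`: 37.1% in this assay

Among the measured compounds shown here, compound 2 stands highest of the two numbers in this assay; its nearest neighbour is compound 1, and the only measured step, a number 11.4 percentage points higher from compound 1 to compound 2 (beyond the scatter), separates them. Compound 3 `Nc1ccccc1NC(=O)c1ccc(COCNc2nc(Nc3cccc(Cl)c3)c3ncn(C4CCCC4)c3n2)cc1` is an unmeasured analogue of compound 2 that differs in one place: (2-aminophenyl)carbamoyl in place of 2-((2-aminophenyl)carbamoyl)ethenyl on an aromatic carbon. For the measured compounds named here, the step of a number 11.4 percentage points higher from compound 1 to compound 2 (beyond the scatter) concerns the group on the aromatic nitrogen and a different part of the shared core, so no measured step bears on the change from compound 2 to compound 3, and the two structures alone give no direction. Since nothing measured points either way, no step beyond the scatter is expected in this assay, and the expected step is a number 6.1 percentage points lower from compound 2 to compound 3 (within the scatter). Compound 3 is therefore estimated at 31% in this assay, with a range from 14% to 48%.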

Compound 3, a percentage reported as inhibition, at one concentration (the size of the read-out at that concentration, not a potency): 36.1%
Beside the measured number, compound 3's estimate is 5.1 percentage points below it; the measured number falls inside the stated range.
By their numbers in this assay, from the lowest: compound 1; then compounds 3 and 2 (each within the scatter of the next).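

In this assay, putting (2-aminophenyl)carbamoyl in place of 2-((2-aminophenyl)carbamoyl)ethenyl, on the aromatic carbon para to a large group, gives a number 1 percentage points lower from compound 2 to compound 3 (within the scatter) in this comparison. Among the compounds shown here, the earlier compounds spoke only to the group on the aromatic nitrogen; this pair is the first reading at this other position, and it shows that the read-out at the tested concentration stays within the scatter when the ethenyl unit is removed. No measurement shown here offers an explanation for this result.

From the compounds shown here alone, it remains open whether an ethyl or propyl chain in place of the ethenyl unit would also leave the read-out unchanged, or whether a hydroxamic acid could stand in for the 2-aminophenyl amide. Also open, going by these compounds, is whether butyl and cyclopentyl on the aromatic nitrogen would differ in the same way alongside (2-aminophenyl)carbamoyl.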